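Methyl moved on the aryl group of the shared core

This account rests on a few compounds, and the source may have more. Where it says the series, first, only, none or still open, it means among the compounds named here.

Measured so far:
compound 1, `Cc1cc(NC(=O)Cn2nnc(-c3cccc(F)c3)n2)n(C2CCCCC2)n1`, gives 96% in an assay on HEK293 cells for activation of Kir3.1/Kir3.2 (Homo sapiens), read by thallium flux; a higher number here means a larger maximal response, a lower number a smaller maximal response
compound 2, `Cc1cc(NC(=O)Cn2nnc(-c3ccnc(F)c3)n2)n(C2CCCCC2)n1`, gives 95% in this assay
compound 3, `Cc1ccc(-c2nnn(CC(=O)Nc3cc(C)nn3C3CCCCC3)n2)cc1`, gives 86% in this assay

Compound 3 sits within the scatter of both others: a number 10 percentage points lower from compound 1 to compound 3 (within the scatter) and a number 9 percentage points lower from compound 2 to compound 3 (within the scatter). The next compound, compound 4, `Cc1cccc(-c2nnn(CC(=O)Nc3cc(C)nn3C3CCCCC3)n2)c1`, differs from compound 3 by 3-methylphenyl in place of 4-methylphenyl on an aromatic carbon. Within the data shown here, no measured step moves a methyl from one position of the aromatic group to another, so the nearest guide is the set of steps that exchange the whole aromatic group on the same carbon: a number 1 percentage points lower from compound 1 to compound 2 (within the scatter), a number 10 percentage points lower from compound 1 to compound 3 (within the scatter) and a number 9 percentage points lower from compound 2 to compound 3 (within the scatter). Every one of them stayed within the scatter, and the group that enters, 3-methylphenyl, is no further from those already seen than they are from one another. On this basis no step beyond the scatter is expected. The expected step is a number 4 percentage points higher from compound 3 to compound 4 (within the scatter). Compound 4 is therefore estimated to give 90% in this assay, with a range from 78% to 100%.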

Compound 4, largest response reached (Emax), in percent of the reference or control that the assay uses: 93%
Estimate against measurement, compound 4: 3 percentage points below; low and high end bracket the measured number.
By their numbers in this assay, from the lowest: compounds 3, 4, 2 and 1 (each within the scatter of the next).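

Moving the methyl from 4-methylphenyl to 3-methylphenyl in this assay gives a number 7 percentage points higher from compound 3 to compound 4 (within the scatter) and is the first measured step that shifts a group around this aromatic ring rather than exchanging the ring. The other two steps to the new compound are also small: 3-methylphenyl in place of 2-fluoropyridin-4-yl gives a number 2 percentage points lower from compound 2 to compound 4 (within the scatter) and methyl in place of fluoro gives a number 3 percentage points lower from compound 1 to compound 4 (within the scatter) so this read-out does not separate methyl from fluoro on this ring. No evidence at hand accounts for any of these steps.

Across the four compounds, every group on this aromatic carbon is a single six-membered aromatic ring with a small substituent. As far as these compounds go, whether a carboxylic acid or a dimethylamino group on that ring, or a morpholine in its place, would give a step beyond the scatter remains open.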